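The source may hold more compounds than are shown below. What is called first, only, known or untested is meant among the compounds shown, and "the series" means these compounds.

In a functional assay on HT-29 cells (Homo sapiens) for antiproliferative activity, read by MTT assay, with a stated time of 72 h (a lower number here means a stronger inhibitor, a higher number a weaker inhibitor), three compounds sharing one core have been measured so far: compound 1 `COc1ccc(N2CCN(C(=S)SCc3ccc4nc(N)nc(N)c4c3)CC2)cc1` gives 1770 nM, compound 2 `Cc1ccccc1N1CCN(C(=S)SCc2ccc3nc(N)nc(N)c3c2)CC1` gives 2950 nM, and compound 3 `Cc1ccc(N2CCN(C(=S)SCc3ccc4nc(N)nc(N)c4c3)CC2)c(C)c1` gives 2970 nM. Compound 3 therefore lies within the scatter of both others, and the three cannot be ranked. Compound 4 `Nc1nc(N)c2cc(CSC(=S)N3CCN(c4ccc(Cl)cc4)CC3)ccc2n1` carries 4-chlorophenyl in place of 2,4-dimethylphenyl on an amine nitrogen in a ring. Three measured steps alter this same aryl group: a 1.7-fold higher number from compound 1 to compound 2 (0.22 log units; within the scatter), a 1.7-fold higher number from compound 1 to compound 3 (0.22 log units; within the scatter) and a 1.0-fold higher number from compound 2 to compound 3 (0.00 log units; within the scatter). Among the measured compounds shown here, all are small, though no chlorine-bearing compound has been measured. No step beyond the scatter is therefore expected in this assay. The expected step is a 1.3-fold lower number from compound 3 to compound 4 (0.11 log units; within the scatter). For compound 4 the estimated value is 2300 nM, with an expected range of 1100 nM to 4800 nM.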

Compound 4, half-maximal inhibitory concentration: 7480 nM
Compound 4: middle estimate off by 3.3-fold (0.51 log units), on the low side, and the stated range ends below it.
By their numbers in this assay, from the lowest: compounds 1, 2 and 3 (each within the scatter of the next); then compound 4.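

In this assay, among the compounds shown here, changing the aryl group on the ring nitrogen can move the number beyond the scatter, which no earlier step here did: 4-chlorophenyl gives a 2.5-fold higher number from compound 3 to compound 4 (0.40 log units; beyond the scatter) and a 2.5-fold higher number from compound 2 to compound 4 (0.40 log units; beyond the scatter). Chloro in place of methoxy on the aromatic carbon gives a 4.2-fold higher number from compound 1 to compound 4 (0.63 log units; beyond the scatter), so this single group swap also has a measurable effect. Nothing measured here explains these steps. Still open, from the compounds shown here alone, is whether the rise belongs to chloro itself. A plain phenyl, 4-methylphenyl or 4-fluorophenyl on the same nitrogen would help separate these possibilities.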